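Extending a methylamino group to a 2-chlorobenzylamino analogue

The compounds below may be only part of what the source reports. "The series", "measured", "known", "first", "only" and "open" are said of these compounds alone.

The account concerns a functional assay on L02 cells (Homo sapiens) for inhibition, read by Griess assay, with stated times of 1 h and 24 h; on this read-out higher numbers stand for weaker inhibition and lower numbers for stronger inhibition. Of the compounds shown here, two have been measured there, both only as limits of the assay. Compound 1, with the structure `CCCc1nn(C)c2c(NCc3ccc(F)cc3)nc(CCc3cccnc3)nc12`, gives < 40000 nM in this assay, which is the limit of < 40000 nM in this assay, at which 1 of the 2 values shown sits. Compound 2, with the structure `CNc1nc(/C=C/c2cc(OC)c(OC)c(OC)c2)nc2ccsc12`, gives > 1000000 nM in this assay, which is the limit of > 1000000 nM in this assay, at which 1 of the 2 values shown sits. Within the data shown here, compound 2 therefore stands at the weak end of what has been recorded, with nothing but a limit to place it, and the one further value shown for compound 1 is itself a limit, so no measured step between the two can be stated.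

Compound 3, with the structure `COc1cc(/C=C/c2nc(NCc3ccccc3Cl)c3sccc3n2)cc(OC)c1OC`, differs from compound 2 in one place: 2-chlorophenyl in place of hydrogen on a saturated chain carbon bound to a nitrogen on an aromatic ring. Among the measured compounds shown here, no step between measured compounds is available to calibrate this change. The expected step from compound 2 to compound 3 is estimated as an at least 5.0-fold lower number from compound 2 to compound 3 (0.69 log units; beyond the scatter), toward stronger inhibition and beyond the usual scatter, though with wide uncertainty. For compound 3 the estimated value in this assay is 200000 nM, expected to lie between 20000 nM and 1000000 nM.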

Compound 3, half-maximal inhibitory concentration: > 1000000 nM
Compound 3: only a limit was reported (the forecaster's own chance of this, stated with the estimate: 55%); middle value at least 5.0-fold (0.69 log units) away from the limit.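

In this assay compound 3 gives > 1000000 nM, which is a limit of the assay. Compound 2 is also recorded only as a limit, so no step can be read between compound 2 and compound 3: the limit of > 1000000 nM in this assay, at which 2 of the 3 values shown sit. The compounds shown leave open whether 2-chlorophenyl in place of hydrogen changes inhibition here at all, and in which direction.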